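A few compounds are considered here, and "the series" means these few. Any claim that something is new, unique, unknown or untested is made for them only; others in the source may bear on it.

Compound 3 `Cc1ccc(S(=O)(=O)OC[C@H]2O[C@@H](OCc3noc(-c4ccc([N+](=O)[O-])cc4)n3)[C@@H]3OC4(CCCC4)O[C@@H]32)cc1` belongs to a small set of sugar-derived compounds tested in a functional assay on HeLa cells (Homo sapiens) for antiproliferative activity, read by sulforhodamine B assay, with a stated time of 48 h; a higher number here means a weaker inhibitor of growth, a lower number a stronger inhibitor of growth. Its result there is not a number but a limit of the assay: in this assay compound 3 gives > 100000 nM. A measured relative is compound 1 `CC(=O)OC[C@H]1O[C@@H](OCc2noc(-c3ccc([N+](=O)[O-])cc3)n2)[C@@H]2OC3(CCCC3)O[C@@H]21`, which carries an acetyl group where compound 3 carries a (4-methylphenyl)sulfonyl group, and in this assay compound 1 gives 17000 nM. Among the compounds with values here, the one measured step, an at least 5.8-fold higher number from compound 1 to compound 3 (0.76 log units; beyond the scatter), ends at the limit of > 100000 nM in this assay, at which 1 of the 3 values shown sits, so its true size is not known. Compound 2 `COc1cc(-c2nc(CO[C@@H]3O[C@H](CSc4ncn[nH]4)[C@H]4OC5(CCCC5)O[C@@H]34)no2)cc(OC)c1OC` carries the (1H-1,2,4-triazol-5-yl)sulfanyl group on a core with a different aryl ring, and in this assay compound 2 gives 37000 nM.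

Compound 4 `O=[N+]([O-])c1ccc(-c2nc(CO[C@@H]3O[C@H](CSc4ncn[nH]4)[C@H]4OC5(CCCC5)O[C@@H]34)no2)cc1` differs from compound 3 in one place: (1H-1,2,4-triazol-5-yl)sulfanyl in place of ((4-methylphenyl)sulfonyl)oxy on a saturated chain carbon bound to a saturated ring carbon. Within the data shown here, no measured step covers this exact exchange. A downward step, toward a stronger inhibitor, is expected because compound 2 gives 37000 nM with the entering group in place and because compound 1 gives 17000 nM once the sulfonyl group is gone. The step from compound 3 to compound 4 is therefore estimated as an at least 2.5-fold lower number from compound 3 to compound 4 (0.39 log units; beyond the scatter). Compound 4 is expected to give about 40000 nM, with a range from 15000 nM to 110000 nM.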

Compound 4, concentration for 50% growth inhibition: 20000 nM
The estimate for compound 4 lay 2.0-fold (0.30 log units) above the measured number; the range from low to high includes it.
By their numbers in this assay, from the lowest: compounds 1, 4 and 2 (each within the scatter of the next, the first and the last beyond it). At a limit, above all of these: compound 3.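

Going by these compounds, exchanging ((4-methylphenyl)sulfonyl)oxy for (1H-1,2,4-triazol-5-yl)sulfanyl on this saturated chain carbon gives an at least 5.0-fold lower number from compound 3 to compound 4 (0.69 log units; beyond the scatter) in this assay, a step whose full size stays unknown, as compound 3 stands at a limit of the assay: the limit of > 100000 nM in this assay, at which 1 of the 4 values shown sits. The triazolylsulfanyl group and the acetoxy group cannot be told apart here, with a 1.2-fold higher number from compound 1 to compound 4 (0.07 log units; within the scatter), so of the three groups seen at this position on the shared core, only ((4-methylphenyl)sulfonyl)oxy goes with a result at the limit. With the triazolylsulfanyl group held in place, the aryl ring also makes no clear difference, as a 1.9-fold lower number from compound 2 to compound 4 (0.27 log units; within the scatter) separates the 3,4,5-trimethoxyphenyl compound from the 4-nitrophenyl compound.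

The compounds shown leave open whether a plain hydroxyl, an amine or a carboxylic acid on this same carbon would stay level with compound 1 and compound 4 or move away from them. They also leave open whether any group at this position can bring the number clearly below that of compound 1, and whether the acetoxy group would behave the same way alongside the 3,4,5-trimethoxyphenyl ring.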